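This account rests on a few compounds, and the source may have more. Where it says the series, first, only, none or still open, it means among the compounds named here.

Measured so far in a functional assay on HEK293 cells for agonist activity at Bombesin receptor subtype-3 (Mus musculus), read by luminescence and calcium flux, with a stated time of 10 min; on this read-out higher numbers stand for an effect only at larger amounts of compound and lower numbers for an effect already at smaller amounts:
- compound 1 `CCC(C)(C)Cc1c[nH]c(CCc2ccc(-n3cccn3)cc2)n1`: 9 nM
- compound 2 `CCC(C)(C)Cc1c[nH]c(CCc2ccc(-c3cccc(C#N)n3)cc2)n1`: 26 nM
- compound 3 `CCC(C)(C)Cc1c[nH]c(CCc2ccc(-c3cccc(N)n3)cc2)n1`: 3.9 nM

Compound 3 stands lowest of the three; its nearest neighbour is compound 1, with a 2.3-fold lower number from compound 1 to compound 3 (0.36 log units; beyond the scatter) separating them, and the gap to compound 2 is wider, a 6.7-fold lower number from compound 2 to compound 3 (0.82 log units; beyond the scatter). Compound 4 `CCC(C)(C)Cc1c[nH]c(CCc2ccc(-c3csnn3)cc2)n1` is the next step: 1,2,3-thiadiazol-4-yl in place of 6-aminopyridin-2-yl on an aromatic carbon. The entering five-membered ring with three hetero atoms and no donor resembles the 1H-pyrazol-1-yl of compound 1 more than the 6-aminopyridin-2-yl of compound 3, and the steps from compound 1 to compound 3 and from compound 2 to compound 3 were both modest. A modest rise in this assay is therefore expected, a 3.1-fold higher number from compound 3 to compound 4 (0.49 log units; beyond the scatter), landing near compound 1. Compound 4 is estimated at 12 nM, range 4 nM to 40 nM.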

Compound 4, half-maximal effective concentration: 11 nM
The estimate for compound 4 lay 1.1-fold (0.04 log units) above the measured number, and the stated range covers the measured number.
By their numbers in this assay, from the lowest: compound 3; then compounds 1 and 4 (each within the scatter of the next); then compound 2.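

In this assay the two five-membered aromatic rings are not told apart at this place, para to a large group: a 1.2-fold higher number from compound 1 to compound 4 (0.09 log units; within the scatter) is all that separates them. The 6-aminopyridin-2-yl stays ahead of 1,2,3-thiadiazol-4-yl, with a 2.8-fold higher number from compound 3 to compound 4 (0.45 log units; beyond the scatter) as the step, while a 2.4-fold lower number from compound 2 to compound 4 (0.37 log units; beyond the scatter) puts 1,2,3-thiadiazol-4-yl ahead of 6-cyanopyridin-2-yl. Nothing available explains these differences. Open, going by these compounds, is how a carboxylic acid or a methoxy group in place of the amino of compound 3 would read.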